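Dichloroacetanilide biaryls: terminal phenyl exchanged for methyl

The compounds below may be only part of what the source reports. "The series", "measured", "known", "first", "only" and "open" are said of these compounds alone.

Measured so far in a functional assay on NCI-H460 cells (Homo sapiens) for cytotoxicity, read by MTT assay, with a stated time of 68 h; on this read-out lower numbers stand for stronger inhibition and higher numbers for weaker inhibition:
- compound 1 `COc1ccc(-c2cccc(NC(=O)C(Cl)Cl)c2)cc1` gives 43300 nM
- compound 2 `O=C(Nc1cccc(-c2ccc(-c3ccccc3)cc2)c1)C(Cl)Cl` gives 10900 nM

Compound 2 stands lowest of the two numbers; its nearest neighbour is compound 1, and the step between them is a 4.0-fold lower number from compound 1 to compound 2 (0.60 log units; beyond the scatter). Among the compounds with values here, that is the only measured step that bears on the next change.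

Compound 3 `Cc1ccc(-c2cccc(NC(=O)C(Cl)Cl)c2)cc1` is compound 2 with one alteration: methyl in place of phenyl on an aromatic carbon. The phenyl whose arrival lowered the number from compound 1 to compound 2 is removed, and a methyl takes its place. Within the data shown here, with no other step available, the working expectation is that the number moves back toward compound 1, a modest rise beyond the scatter rather than a full return, since methyl is not methoxy. The expected step from compound 2 to compound 3 in this assay is a 2.8-fold higher number from compound 2 to compound 3 (0.44 log units; beyond the scatter). Compound 3 is therefore estimated at 30000 nM in this assay, with a range from 12000 nM to 75000 nM.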

Compound 3, half-maximal inhibitory concentration: 8000 nM
Beside the measured number, compound 3's estimate is 3.8-fold (0.57 log units) above it, and the stated range ends above it.
By their numbers in this assay, from the lowest: compounds 3 and 2 (each within the scatter of the next); then compound 1.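

Exchanging the terminal phenyl for methyl gives a 1.4-fold lower number from compound 2 to compound 3 (0.13 log units; within the scatter) in this assay, so the phenyl is not required at this position to hold the number seen for compound 2. Going from one carbon to six at this position leaves the two compounds within the scatter of each other, while the methoxy-to-methyl exchange gives a 5.4-fold lower number from compound 1 to compound 3 (0.73 log units; beyond the scatter) and sets compound 1 apart from both. Nothing measured here explains why methoxy differs from methyl and phenyl at this position.

Open, going by these compounds, is whether the separation of compound 1 extends to other groups attached through oxygen, such as ethoxy or hydroxyl. Also open, on these data alone, is how an amine, a carboxylic acid or a longer alkyl chain would read at this position.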